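The source may hold more compounds than are shown below. What is called first, only, known or untested is meant among the compounds shown, and "the series" means these compounds.

Working notes on the series. In a functional assay on MCF7 cells (Homo sapiens) for cytotoxicity, read by MTT assay, with a stated time of 48 h (on this read-out higher numbers stand for weaker inhibition and lower numbers for stronger inhibition), compound 1 `C#CCNC(=O)Nc1cccc(CCl)c1` gives 1480 nM and compound 2 `C#CCNC(=O)Nc1cccc(COc2ccc(C(=O)OC)cc2)c1` gives 74900 nM, while compound 3 `C#CCNC(=O)Nc1cccc(CNCc2ccccc2)c1` gives 343000 nM as the highest of the three numbers. Compound 3 therefore reads as the weakest of the three, with compound 2 nearest and compound 1 furthest, and both gaps lie beyond the scatter.

Compound 4 `C#CCNC(=O)Nc1cccc(CNCc2ccc(C)cc2)c1` differs from compound 3 in one place: methyl in place of hydrogen on an aromatic carbon as methyl in place of hydrogen on an aromatic carbon, which turns phenyl into 4-methylphenyl. Going by the values given here, no two measured compounds differ in only one place, so the series holds no direct precedent for this change. In this assay a small step toward a lower number is expected, most likely within the scatter. The expected step is a 1.4-fold lower number from compound 3 to compound 4 (0.14 log units; within the scatter) in estimated terms. The wide spread among the measured compounds argues for a broad range. The estimate for compound 4 is 250000 nM with an expected range from 80000 nM to 600000 nM on this read-out.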

Compound 4, half-maximal inhibitory concentration: 49900 nM
The estimate for compound 4 lay 5.0-fold (0.70 log units) above the measured number, and the stated range ends above it.
By their numbers in this assay, from the lowest: compound 1; then compounds 4 and 2 (each within the scatter of the next); then compound 3.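

Methyl in place of hydrogen on an aromatic carbon, para to a large group, gives a 6.9-fold lower number from compound 3 to compound 4 (0.84 log units; beyond the scatter) in this assay and supplies the first comparison in the series that isolates a single change. The step from phenyl to 4-methylphenyl lies beyond the scatter, so on this read-out the number responds to a single added carbon at this place. This is one pair only, and it sets no trend for other groups at the same place.

As far as these compounds go, whether ethyl, methoxy or chlorine at the same place moves the number in the same direction remains open. Also open, from the compounds shown here alone, is whether an amine or a carboxylic acid there would reverse the step. No available evidence bears on why the number moves with this change.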